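Working notes on the amide variations of compound 1

The compounds below may be only part of what the source reports. "The series", "measured", "known", "first", "only" and "open" are said of these compounds alone.

Measured in a functional assay on HeLa cells (Homo sapiens) for inhibition, read by MTT assay, with a stated time of 72 h; a lower number here means a stronger inhibitor, a higher number a weaker inhibitor:
compound 1, `C=CC(=O)Nc1cccc(Oc2nc(Nc3cccc(C#N)c3)nc3ccsc23)c1`: 6390 nM
compound 2, `C/C=C/C(=O)Nc1cccc(Oc2nc(Nc3cccc(C#N)c3)nc3ccsc23)c1`: 23600 nM
compound 3, `CC(C)=CC(=O)Nc1cccc(Oc2nc(Nc3cccc(C#N)c3)nc3ccsc23)c1`: 19800 nM

Compound 3 stands second highest of the three numbers. For the measured compounds named here, its nearest neighbour is compound 2, with a 1.2-fold lower number from compound 2 to compound 3 (0.08 log units; within the scatter), a gap within the scatter; its only step beyond the scatter leads back to compound 1, a 3.1-fold higher number from compound 1 to compound 3 (0.49 log units; beyond the scatter).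

Compound 4, `CC/C=C/C(=O)Nc1cccc(Oc2nc(Nc3cccc(C#N)c3)nc3ccsc23)c1`, has the same atoms as compound 3, joined differently: but-1-en-1-yl in place of 2-methylprop-1-en-1-yl on a carbonyl carbon. Going by the values given here, two measured steps bear on this. Both replacements of the vinyl group on the carbonyl carbon, a 3.7-fold higher number from compound 1 to compound 2 (0.57 log units; beyond the scatter) and a 3.1-fold higher number from compound 1 to compound 3 (0.49 log units; beyond the scatter), gave modest rises in the number, beyond the scatter. Between the two replaced variants themselves, a 1.2-fold lower number from compound 2 to compound 3 (0.08 log units; within the scatter) stayed within the scatter, so the arrangement of the four carbons on the chain did not separate compound 2 from compound 3. Compound 4 again carries a four-carbon chain with one double bond on the carbonyl carbon, so the step from compound 3 is expected to stay within the scatter, a 1.0-fold higher number from compound 3 to compound 4 (0.00 log units; within the scatter). The estimate for compound 4 in this assay is 20000 nM, with a range from 8000 nM to 50000 nM.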

Compound 4, half-maximal inhibitory concentration: 69400 nM
The estimate for compound 4 lay 3.5-fold (0.54 log units) below the measured number; measured number above the stated range.
By their numbers in this assay, from the lowest: compound 1; then compounds 3 and 2 (each within the scatter of the next); then compound 4.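

In this assay, for the compounds shown here, the way the chain is joined proves to matter at this position: but-1-en-1-yl and 2-methylprop-1-en-1-yl have the same atoms and the same counts of double bonds, donors and acceptors, yet a 3.5-fold higher number from compound 3 to compound 4 (0.54 log units; beyond the scatter) lies beyond the scatter, a separation that the earlier compounds, none of which were isomers, could not show. Going by these compounds alone, the unbranched line also extends further than before, with methyl in place of hydrogen on a saturated chain carbon bound to a double-bonded chain carbon giving a 2.9-fold higher number from compound 2 to compound 4 (0.47 log units; beyond the scatter) and the full change from the vinyl group giving an 11-fold higher number from compound 1 to compound 4 (1.04 log units; beyond the scatter) as the only large step in the set, although compound 3 sits off this line and stays within the scatter of compound 2. No measurement available here bears on the reason for these steps.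

Open, going by these compounds, is whether a longer chain such as pent-1-en-1-yl would carry the number further up, or whether an amine such as dimethylamino at the end of the but-1-en-1-yl chain would move it in either direction. Also open, on these data alone, is how an ethyl group, with no double bond, would compare with the vinyl group of compound 1 on the same carbonyl carbon.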